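A few compounds are considered here, and "the series" means these few. Any claim that something is new, unique, unknown or untested is made for them only; others in the source may bear on it.

Working notes on the series. The shared core is that of compound 1 `O=C(/C=C/c1ccc([N+](=O)[O-])o1)c1ccc(I)cc1`. In an ADME assay on THP-1 cells (Homo sapiens) for cytotoxicity, read by resazurin assay, with a stated time of 72 h (on this read-out lower numbers stand for higher toxicity in this test and higher numbers for lower toxicity in this test), compound 1 gives 49500 nM. Compound 2 `CC(C)(C)c1ccc(C(=O)/C=C/c2ccc([N+](=O)[O-])o2)cc1` carries tert-butyl in place of iodo on an aromatic carbon. In this assay compound 2 gives > 50000 nM, which is a limit of the assay and not a number. Compound 3 `CC(C)(C)c1ccc(C(=O)/C=C/c2ccco2)cc1` carries hydrogen in place of nitro on an aromatic carbon. In this assay compound 3 gives > 50000 nM, again a limit of the assay and not a number. The step of a number no lower from compound 1 to compound 2 (the limit leaves the size open) and the step that the two limits leave unreadable from compound 2 to compound 3 cannot be sized owing to the limit of > 50000 nM in this assay, at which 2 of the 3 values shown sit. Compound 2 thus stands at that limit, as does one other value shown.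

Compound 4 `CSc1ccc(C(=O)/C=C/c2ccc([N+](=O)[O-])o2)cc1` differs from compound 2 by methylsulfanyl in place of tert-butyl on an aromatic carbon. Neither measured step gives a readable size that bears on this change; both only show values at or next to the limit. Compound 4 is therefore expected to remain near the limit, with the expected step of an at least 1.1-fold lower number from compound 2 to compound 4 (0.04 log units; that floor lies within the scatter) lying within the scatter. The estimate for compound 4 in this assay is 45000 nM, with a range from 20000 nM to 100000 nM.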

Compound 4, half-maximal cytotoxic concentration: 13100 nM
Estimate against measurement, compound 4: 3.4-fold (0.54 log units) above; the whole stated range lies above it.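

In this assay, within the data shown here, the group on this aromatic carbon now has a readable effect for the first time, with a 3.8-fold lower number from compound 1 to compound 4 (0.58 log units; beyond the scatter) when methylsulfanyl replaces iodo. With the nitro group kept in compounds 1, 2 and 4, the change at this position alone separates the values. Against tert-butyl the change gives an at least 3.8-fold lower number from compound 2 to compound 4 (0.58 log units; beyond the scatter) and that size is only a floor, because compound 2 stands at a limit of the assay and not at a number: the limit of > 50000 nM in this assay, at which 2 of the 4 values shown sit.

As far as these compounds go, whether the lower number follows the sulfur of methylsulfanyl or something else about the group stays open, and a methoxy group or an amine at the same place would bear on that. Among these compounds, also open is whether the nitro group matters once methylsulfanyl is present, since the only comparison without it rests on limits that cannot be read.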